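Amino-to-Ether Swap Tested on a Trifluoromethyl Analogue

The source may hold more compounds than are shown below. What is called first, only, known or untested is meant among the compounds shown, and "the series" means these compounds.

Measured compounds:
Compound 1, `Clc1cc(-c2ccn3c(CC4CC4)nnc3c2Cl)ccc1NC1CCOCC1`, gives 19.5 nM
Compound 2, `FC(F)(F)c1c(-c2ccc(NC3CCOCC3)c(Cl)c2)ccn2c(CC3CC3)nnc12`, gives 3.8 nM

In an assay on cells for binding affinity to metabotropic glutamate receptor 2 (Homo sapiens), read by scintillation proximity assay (a higher number here means weaker binding, a lower number tighter binding), compound 1 gives 19.5 nM, while compound 2 gives 3.8 nM. Going by the values given here, the only measured step is a 5.1-fold lower number from compound 1 to compound 2 (0.71 log units; beyond the scatter), a trifluoromethyl in place of chloro on an aromatic carbon. Compound 2 therefore holds the lowest of the two numbers in this assay, and compound 1 is its nearest neighbour.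

Compound 3, `O[C@H]1CC[C@H](Oc2ccc(-c3ccn4c(CC5CC5)nnc4c3C(F)(F)F)cc2Cl)CC1`, differs from compound 2 by (4-hydroxycyclohexyl)oxy in place of (oxan-4-yl)amino on an aromatic carbon. Among the compounds with values here, none of the measured steps bears on this change: the one step seen, a 5.1-fold lower number from compound 1 to compound 2 (0.71 log units; beyond the scatter), alters a different position and leaves the amino substituent untouched. The expectation for compound 3 therefore rests on compound 2 alone, and a change of modest size in either direction, or none beyond the scatter, is equally plausible. Compound 3 is estimated at 8 nM, within 2 nM to 30 nM, which would mean an expected step of a 2.1-fold higher number from compound 2 to compound 3 (0.32 log units; beyond the scatter).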

Compound 3, dissociation constant: 3 nM
Estimate against measurement, compound 3: 2.7-fold (0.43 log units) above; low and high end bracket the measured number.
By their numbers in this assay, from the lowest: compounds 3 and 2 (each within the scatter of the next); then compound 1.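

In this assay, (4-hydroxycyclohexyl)oxy in place of (oxan-4-yl)amino gives a 1.3-fold lower number from compound 2 to compound 3 (0.10 log units; within the scatter), so the two groups cannot be told apart at this position. Going by these compounds alone, the earlier step changed another site and left the amino substituent untouched, so this is the first reading here: the linking nitrogen and the oxane ring can both be exchanged at once, for an oxygen and a ring of carbon only bearing a hydroxyl, without a change beyond the scatter. No measurement at hand says why the two groups read alike.

The compounds shown leave open how each part of the swap acts alone, which (oxan-4-yl)oxy or (4-hydroxycyclohexyl)amino would separate. Also open, going by these compounds, is how the other stereoisomer of the (4-hydroxycyclohexyl)oxy group, or an amine in place of its hydroxyl, would read.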